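A Smaller Substituent on the Sulfonyl Ring

This account rests on a few compounds, and the source may have more. Where it says the series, first, only, none or still open, it means among the compounds named here.

Compound 1, `CCN(CC)c1ccc2cc(C(=O)c3ccc(N4CCN(C(=O)CN5CCNCC5)CC4)cc3)oc2c1`: in a functional assay on HCT-116 cells (Homo sapiens) for cytotoxicity, read by MTT assay, with a stated time of 48 h (on this read-out higher numbers stand for weaker inhibition and lower numbers for stronger inhibition), compound 1 gives 1870 nM.
Compound 2, `CCN(CC)c1ccc2cc(C(=O)c3ccc(N4CCN(C(=O)CN5CCN(S(=O)(=O)c6ccc(OC(F)(F)F)cc6)CC5)CC4)cc3)oc2c1`: in this assay compound 2 gives 7680 nM.

Both compounds share the same core and differ only at the far end of the chain on the piperazine amide: compound 1 carries a free piperazine ring, while compound 2 carries a sulfonyl group bearing a 4-(trifluoromethoxy)phenyl ring on that piperazine. Of the two numbers in this assay, compound 2 has the higher one, and the gap to compound 1 lies beyond the usual scatter of repeated measurements.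

Compound 3, `CCN(CC)c1ccc2cc(C(=O)c3ccc(N4CCN(C(=O)CN5CCN(S(=O)(=O)c6ccc(F)cc6)CC5)CC4)cc3)oc2c1`, keeps the sulfonyl arrangement of compound 2 and changes only the substituent on the aromatic ring: fluoro in place of trifluoromethoxy on an aromatic carbon, a change from 4-(trifluoromethoxy)phenyl to 4-fluorophenyl. For the measured compounds named here, no measured pair shows what such a change does here. With the bulk of the molecule untouched, the step of a 1.3-fold lower number from compound 2 to compound 3 (0.11 log units; within the scatter) is expected to be small, at most a slight lowering of the number, and likely within the scatter. Compound 3 is therefore estimated to give about 6000 nM, with a range from 2500 nM to 15000 nM.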

Compound 3, half-maximal inhibitory concentration: > 40000 nM
Compound 3 gave a limit, no number; the forecaster's own chance of this, stated with the estimate: 5%; middle value at least 6.6-fold (0.82 log units) from the limit.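

In this assay compound 3 gives > 40000 nM, which is a limit of the assay and not a number: the limit of > 40000 nM in this assay, at which 1 of the 3 values shown sits.

This shows that the substituent on the sulfonyl ring is not a passive end of the molecule, since fluoro in place of trifluoromethoxy, on an aromatic carbon para to a large group, gives an at least 5.2-fold higher number from compound 2 to compound 3 (0.71 log units; beyond the scatter). The earlier pair showed only that adding a whole arylsulfonyl unit to the free piperazine goes with a higher number; here, with (4-fluorophenyl)sulfonyl in place of hydrogen on the amine nitrogen in the ring, the step is an at least 21-fold higher number from compound 1 to compound 3 (1.33 log units; beyond the scatter), so the outcome of that addition depends on what the aromatic ring carries.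

With only two substituents on this ring, the compounds shown cannot say whether trifluoromethoxy is unusually favourable or fluoro unusually poor. A methoxy group, a chlorine atom or an amine at the same place, or a ring with hydrogen there, would show how the number follows the group.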